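Oxygen substituent change, compound 1 to compound 4

A few compounds are considered here, and "the series" means these few. Any claim that something is new, unique, unknown or untested is made for them only; others in the source may bear on it.

Measured so far:
compound 1 `O=S(=O)(NCCNC(=S)Nc1cccc(Cl)c1)c1ccc(-c2ccccc2OCc2cccc(O)c2)s1`: 5800 nM
compound 2 `O=C(NCCNS(=O)(=O)c1ccc(-c2ccccc2OCc2cccc(O)c2)s1)Nc1cc(Cl)cc(Cl)c1`: > 50000 nM (a limit of the assay)
compound 3 `Cc1cc(C)cc(NC(=O)NCCNS(=O)(=O)c2ccc(-c3ccccc3OCc3cccc(O)c3)s2)c1`: 5800 nM

In a functional assay on RS4-11 cells (Homo sapiens) for inhibition, read by CCK-8 assay, with a stated time of 48 h (a lower number here means a stronger inhibitor, a higher number a weaker inhibitor), compound 1 gives 5800 nM, level with compound 3 at 5800 nM. Compound 2 is known only as a limit, > 50000 nM.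

Compound 4 `O=[N+]([O-])c1ccc(Oc2ccccc2-c2ccc(S(=O)(=O)NCCNC(=S)Nc3cccc(Cl)c3)s2)cc1` keeps the rest of compound 1 and changes one group: 4-nitrophenyl in place of 3-hydroxybenzyl on an oxygen on an aromatic ring. 4-Nitrophenyl thus stands in place of 3-hydroxybenzyl on an oxygen on an aromatic ring.

Among the compounds with values here, no measured step touches this place, since compounds 1, 2 and 3 all carry 3-hydroxybenzyl. The available steps bear only indirectly, all at the other end of the molecule. One is flat, no change at the digits printed from compound 1 to compound 3 (within the scatter). The other two are large, an at least 8.6-fold higher number from compound 1 to compound 2 (0.93 log units; beyond the scatter) and an at least 8.6-fold lower number from compound 2 to compound 3 (0.93 log units; beyond the scatter). They show that a single change in this series can either leave the number untouched or take it to the limit.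

Within the data shown here, with no direct precedent, the expectation stays close to compound 1 and leans towards a higher number, and a limit reading remains possible. The expected step is small, a 1.4-fold higher number from compound 1 to compound 4 (0.14 log units; within the scatter). For compound 4 the estimated value is 8000 nM, with an expected range of 2000 nM to 35000 nM.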

Compound 4, half-maximal inhibitory concentration: > 50000 nM
Compound 4: a limit, no number (the forecaster's own chance of this, stated with the estimate: 20%); middle value at least 6.2-fold (0.79 log units) away from the limit.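

In this assay, within the data shown here, the only measured change at this position, on an oxygen on an aromatic ring, gives an at least 8.6-fold higher number from compound 1 to compound 4 (0.93 log units; beyond the scatter), so this end of the molecule is not free to vary in the way the flat step from compound 1 to compound 3 might have suggested for the series. For compound 4, the reading of > 50000 nM is a limit of the assay and not a number. Compound 2 and compound 4 each lie one change away from compound 1, at different places, and so the same limit is now reached from two ends of the molecule: the limit of > 50000 nM in this assay, at which 2 of the 4 values shown sit.

The change from (3-hydroxybenzyl)oxy to 4-nitrophenoxy alters several features together, and the compounds shown cannot say whether the loss of the hydroxy group, the entry of the nitro group or the shift from benzyl to phenyl carries the step. As far as these compounds go, how a plain benzyl, a 3-hydroxyphenyl or a 4-aminophenyl group on that oxygen would read stays open, as does whether any group there gives a lower number than compound 1 does at 5800 nM.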